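A few compounds are considered here, and "the series" means these few. Any claim that something is new, unique, unknown or untested is made for them only; others in the source may bear on it.

Compound 1 `COc1cnc(C[S+]([O-])c2nc3cc(OC(F)F)ccc3[nH]2)c(C)c1OC` carries a methoxy group on its six-membered aromatic ring with one nitrogen together with a difluoromethoxy group on the benzimidazole-type part of the shared core. In an ADME assay for pharmacokinetics, at pH 7.4 (a higher number here means that the compound lasts longer, a lower number that the compound disappears faster), compound 1 gives 60 h. Compound 2 `COc1ccnc(C[S+]([O-])c2nc3cc(OC(F)F)ccc3[nH]2)c1C` differs from compound 1 only by hydrogen in place of methoxy on an aromatic carbon, and in this assay compound 2 gives 3 h, so that a 20-fold lower number from compound 1 to compound 2 (1.30 log units; beyond the scatter). Compound 3 `COc1cnc(C[S+]([O-])c2nc3cc(OCC(F)(F)F)ccc3[nH]2)c(C)c1OC` keeps the methoxy group and differs from compound 1 by 2,2,2-trifluoroethyl in place of difluoromethyl on an oxygen on an aromatic ring; in this assay compound 3 gives 130 h, and a 2.2-fold higher number from compound 1 to compound 3 (0.34 log units; beyond the scatter). Of the three measured compounds, compound 3 shows the longest half-life, its steps to compound 1 and to compound 2 both lying beyond the scatter.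

Compound 4 `COc1ccnc(C[S+]([O-])c2nc3cc(OCC(F)(F)F)ccc3[nH]2)c1C` has not yet been measured. It stands to compound 3 as compound 2 stands to compound 1: the change is hydrogen in place of methoxy on an aromatic carbon, while the two cores differ by 2,2,2-trifluoroethyl in place of difluoromethyl on an oxygen on an aromatic ring. The surroundings of the change are described in exactly the same words for both pairs, so this is the same change, occurring for the second time among the four compounds. Going by the values given here, the only guide to its effect is the single earlier pair, and nothing indicates whether the trifluoroethoxy core would answer differently. Because a 20-fold lower number from compound 1 to compound 2 (1.30 log units; beyond the scatter), the expected step in this assay is a 20-fold lower number from compound 3 to compound 4 (1.30 log units; beyond the scatter). Compound 4 is therefore estimated at 6.5 h, with a likely range from 2.5 h to 17 h.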

Compound 4, half-life in the ADME assay: 5 h
For compound 4 the middle estimate is 1.3-fold (0.11 log units) above the measured one, within the range that was stated.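

In the ADME assay compound 3 gives 130 h and compound 4 gives 5 h. In the ADME assay, hydrogen in place of methoxy on an aromatic carbon gives a 26-fold lower number from compound 3 to compound 4 (1.41 log units; beyond the scatter), and this step lies within the scatter of the one seen on the core of compound 1: the same change on two cores in the ADME assay, a 20-fold lower number (1.30 log units; beyond the scatter) from compound 1 to compound 2 and a 26-fold lower number (1.41 log units; beyond the scatter) from compound 3 to compound 4, 1.3-fold (0.11 log units) apart, within the scatter of two such steps. The second change, 2,2,2-trifluoroethyl in place of difluoromethyl on an oxygen on an aromatic ring, gives a 1.7-fold higher number from compound 2 to compound 4 (0.22 log units; within the scatter), a step that is small on its own and does not differ from its counterpart on the core that keeps the methoxy group: the same change on two cores in the ADME assay, a 2.2-fold higher number (0.34 log units; beyond the scatter) from compound 1 to compound 3 and a 1.7-fold higher number (0.22 log units; within the scatter) from compound 2 to compound 4, 1.3-fold (0.11 log units) apart, within the scatter of two such steps. In a physicochemical assay for acid dissociation, compound 3 gives 8.61 and compound 4 gives 8.51. Going by these compounds alone, in the physicochemical assay the first change gives a number 0.10 log units lower from compound 3 to compound 4 (within the scatter), but that is a single pair, and the two pairs of steps show only that each change carried over between these two cores, not that it would do so on any other core or why the half-life moves as it does.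

The compounds shown leave open whether the large step depends on hydrogen as the incoming group, or whether an ethoxy group or a chlorine atom at the same place would give a similar one. They also leave open whether the carry-over would persist if the group on the oxygen were a longer chain, such as a pentafluoropropyl group.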